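Methyl in place of methoxy: an exposure estimate

The compounds below may be only part of what the source reports. "The series", "measured", "known", "first", "only" and "open" are said of these compounds alone.

Compound 1 `COc1nc2ccc(C#N)cc2cc1[C@@H](c1cccc(C)c1F)[C@@](O)(CCN(C)C)c1cc(SC)nc(SC)c1`: 2400 ng.h/mL
Compound 2 `CCSc1cc([C@](O)(CCN(C)C)[C@@H](c2cc3cc(C#N)ccc3nc2OC)c2cccc(OC)c2F)cc(SCC)n1`: 1400 ng.h/mL

In an ADME assay on the whole organism (Mus musculus, strain CD-1) for pharmacokinetics, at a dose of 10 mg/kg by the oral route (on this read-out higher numbers stand for higher exposure at the dose given and lower numbers for lower exposure), compound 2 gives 1400 ng.h/mL and compound 1 gives 2400 ng.h/mL. These two values lie within the usual scatter of each other, so compound 2 stands level with compound 1 on these numbers.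

Compound 3 `CCSc1cc([C@](O)(CCN(C)C)[C@@H](c2cc3cc(C#N)ccc3nc2OC)c2cccc(C)c2F)cc(SCC)n1` differs from compound 2 in one place: methyl in place of methoxy on an aromatic carbon. This is methyl in place of methoxy on an aromatic carbon, so 2-fluoro-3-methoxyphenyl becomes 2-fluoro-3-methylphenyl. For the measured compounds named here, no measured pair shows this change on its own, so the data give no direct guide to its size or direction. The expected step, a 1.3-fold higher number from compound 2 to compound 3 (0.11 log units; within the scatter), therefore stays within the scatter. For compound 3 the estimated value is 1800 ng.h/mL, with an expected range of 800 ng.h/mL to 4000 ng.h/mL.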

Compound 3, area under the concentration-time curve: 4000 ng.h/mL
For compound 3 the middle estimate is 2.2-fold (0.35 log units) below the measured one, within the range that was stated.
By their numbers in this assay, from the lowest: compounds 2, 1 and 3 (each within the scatter of the next, the first and the last beyond it).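

Methyl in place of methoxy, ortho to a fluoro group, gives a 2.9-fold higher number from compound 2 to compound 3 (0.46 log units; beyond the scatter) in this assay, the first direct reading of this change, and it shows a modest rise that clears the scatter. With methyl held at this position, a group of 12 heavy atoms in place of a group of 10 heavy atoms gives a 1.7-fold higher number from compound 1 to compound 3 (0.22 log units; within the scatter), so compound 1 and compound 3 stand level on these numbers. Nothing measured here speaks to what lies behind the rise in exposure.

A single pair leaves open whether the methoxy-to-methyl gain would also appear with the group of 10 heavy atoms in place. On these data alone, how a chloro, an ethyl or a hydroxy group would read at this same position also remains open.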